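The compounds below may be only part of what the source reports. "The series", "measured", "known", "first", "only" and "open" are said of these compounds alone.

Measured compounds:
compound 1 `CC(C)CCOc1nc(C(C)(C)C)ccc1CNC(=O)C(C)c1ccc(NS(C)(=O)=O)c(F)c1`, 0.8 nM
compound 2 `CC(C(=O)NCc1ccc(C(C)(C)C)nc1OC1CCCC1)c1ccc(NS(C)(=O)=O)c(F)c1`, 1.5 nM
compound 3 `CC(C)CCOc1cc(C(C)(C)C)ccc1CNC(=O)C(C)c1ccc(NS(C)(=O)=O)c(F)c1`, 0.6 nM

All three were run in an assay on cells for antagonist activity at transient receptor potential cation channel subfamily V member 1 (Homo sapiens), read by FLIPR and calcium flux, with a stated time of 6 min; on this read-out higher numbers stand for weaker inhibition and lower numbers for stronger inhibition. Compound 1 gives 0.8 nM, compound 2 gives 1.5 nM and compound 3 gives 0.6 nM. Compound 1 and compound 3 sit within the scatter of each other; compound 2 sits beyond the scatter from compound 3 only.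

Among the compounds with values here, the single change from compound 1 to compound 2 is cyclopentyl in place of isopentyl on an oxygen on an aromatic ring, and it made a 1.9-fold higher number from compound 1 to compound 2 (0.27 log units; within the scatter).

The difference between the core of compound 1 and the core of compound 3 is not broken down here.

Compound 4 `CC(C(=O)NCc1ccc(C(C)(C)C)cc1OC1CCCC1)c1ccc(NS(C)(=O)=O)c(F)c1` is not yet measured. It differs from compound 3 by cyclopentyl in place of isopentyl on an oxygen on an aromatic ring, which is the same change, at the same kind of place, as that from compound 1 to compound 2.

In this assay the step is expected to be a 1.8-fold higher number from compound 3 to compound 4 (0.26 log units; within the scatter), resting on the earlier step, because a 1.9-fold higher number from compound 1 to compound 2 (0.27 log units; within the scatter) lies within the scatter. Compound 4 is therefore expected to give about 1.1 nM, with a range from 0.5 nM to 2.5 nM.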

Compound 4, inhibition constant: 1.8 nM
The estimate for compound 4 lay 1.6-fold (0.21 log units) below the measured number; the measured number falls inside the stated range.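

In this assay, within the data shown here, cyclopentyl in place of isopentyl on an oxygen on an aromatic ring gives a 3.0-fold higher number from compound 3 to compound 4 (0.48 log units; beyond the scatter), and the gap between this step and the earlier one cannot be told from scatter: the same change on two cores in this assay, a 1.9-fold higher number (0.27 log units; within the scatter) from compound 1 to compound 2 and a 3.0-fold higher number (0.48 log units; beyond the scatter) from compound 3 to compound 4, 1.6-fold (0.20 log units) apart, within the scatter of two such steps As far as these four compounds go, the change carries from the core of compound 1 to the core of compound 3 in the same direction, although only the step on the core of compound 3 stands beyond the scatter. This does not show that the two cores respond differently, that the step would hold on any further core, or what lies behind it.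

Still open, as far as these compounds go, is how other groups on that oxygen would read, such as an ethyl chain, a cyclohexyl ring or a chain ending in an amine. Also open, from the compounds shown here alone, is whether the step would hold with trifluoromethyl in place of the tert-butyl group.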